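The source may report more compounds than this note shows. Statements on the series, on what has been measured and on what is new or still open speak of the compounds shown alone.

Of the compounds shown here, three sharing one core have been measured in a functional assay on HEK293T cells for agonist activity at histamine H2 receptor (Homo sapiens), read by beta-arrestin recruitment; a higher number here means that more compound is needed for the effect, a lower number that less compound is needed. Compound 1 `Cc1nc(N)sc1CCCN/C(N)=N/C(=O)NC1CCCCC1` carries a cyclohexyl group on an amide-type nitrogen, and in this assay compound 1 gives 389 nM. Compound 2 `Cc1nc(N)sc1CCCN/C(N)=N/C(=S)N[C@H](C)c1ccccc1` gives 372 nM in this assay, a number that lies within the usual scatter of that of compound 1. Compound 3 `CCCCCCNC(=O)/N=C(\N)NCCCc1sc(N)nc1C` has hexyl where compound 1 has cyclohexyl. In this assay compound 3 gives 85.1 nM, so among the three, compound 1 sits at the end where more compound is needed, with compound 2 beside it.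

Compound 4 `CCCNC(=O)/N=C(\N)NCCCc1sc(N)nc1C` has not yet been measured. Its difference from compound 1 is propyl in place of cyclohexyl on an amide-type nitrogen; cut one bond further out, the change reads cyclohexylamino to propylamino.

Among the measured compounds shown here, one measured step bears on this: a 4.6-fold lower number from compound 1 to compound 3 (0.66 log units; beyond the scatter). Hexyl in place of cyclohexyl lowered the number. Propyl is a shorter chain than hexyl, and no measured pair shows how chain length matters at this nitrogen, so the hexyl result is only a partial guide. A step in the same direction but smaller than that one is expected: a 1.9-fold lower number from compound 1 to compound 4 (0.29 log units; within the scatter). Compound 4 is therefore estimated at 200 nM in this assay, within a range from 80 nM to 500 nM.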

Compound 4, half-maximal effective concentration: 170 nM
Compound 4: middle estimate off by 1.2-fold (0.07 log units), on the high side, within the range that was stated.
By their numbers in this assay, from the lowest: compounds 3 and 4 (each within the scatter of the next); then compounds 2 and 1 (each within the scatter of the next).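

In this assay, propyl in place of cyclohexyl gives a 2.3-fold lower number from compound 1 to compound 4 (0.36 log units; beyond the scatter), so the lower number seen with hexyl at this amide-type nitrogen is not a single case, and it appears here with a group of 3 carbons in place of 6. The two open chains cannot be told apart in this assay: the comparison reads a 2.0-fold higher number from compound 3 to compound 4 (0.30 log units; within the scatter), so no effect of chain length can be read from these two compounds at this nitrogen. No outside measurement bears on the reason for this result.

Still open, as far as these compounds go, is how far the chain can be altered, for instance whether ethyl, a shorter chain, or octyl, a longer one, would fall in line with propyl and hexyl, and whether a branched chain such as isopropyl would behave like them or like cyclohexyl. Also open, from the compounds shown here alone, is whether a smaller ring such as cyclopentyl would give a number closer to that of cyclohexyl or to those of the open chains, and what a hydroxyl or an amine at the end of the chain would do.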